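Removing a tert-Butyl Group: Expected Acid Dissociation

The source may report more compounds than this note shows. Statements on the series, on what has been measured and on what is new or still open speak of the compounds shown alone.

Compound 1 `CC(C)(C)c1ccc(Oc2ccc3c(NCCCNCc4ccco4)ccnc3c2)cc1` and compound 2 `COc1cccc(CNCCCNc2ccnc3cc(Cc4ccc(F)cc4)ccc23)c1O` have both been measured in a physicochemical assay for acid dissociation. Compound 1 gives 9.28, and compound 2 gives 9.47 in this assay. The two numbers differ by an amount within the scatter of repeated measurements, and compound 1 therefore stands alongside compound 2 rather than apart from it. Compound 3 `c1ccc(Oc2ccc3c(NCCCNCc4ccco4)ccnc3c2)cc1` has not yet been measured in this assay. It differs from compound 1 in one place: hydrogen in place of tert-butyl on an aromatic carbon. The group that leaves sits para to a large group, and the site of change is far from the nitrogen atoms of the chain. Among the compounds with values here, no step between measured compounds is available for this change, and a step of no more than the scatter is expected in this assay, in neither direction. Compound 3 is estimated to give 9.25, with a range from 8.9 to 9.6. The expected step of a number 0.03 log units lower from compound 1 to compound 3 (within the scatter) is thus within the scatter.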

Compound 3, acid dissociation constant: 9.28
Compound 3: middle estimate off by 0.03 log units, on the low side; measured number inside the range.
By their numbers in this assay, from the lowest: compounds 1, 3 and 2 (each within the scatter of the next).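

In this assay, hydrogen in place of tert-butyl on an aromatic carbon gives no change at the digits printed from compound 1 to compound 3 (within the scatter). Within the data shown here, this is the first step between measured compounds that differ in one place, and it shows that removing all four heavy atoms of the tert-butyl group at this place, para to a large group, leaves the read-out within the scatter. Nothing available accounts for this result, so it stands as an observation only.

The compounds shown leave open whether an amine or a carboxylic acid at the same place on the ring would also stay within the scatter in this assay, since the only group exchanged so far is a tert-butyl group made of carbon alone. They also leave open what a longer chain between the nitrogen atoms would do to the read-out.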